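A few compounds are considered here, and "the series" means these few. Any claim that something is new, unique, unknown or untested is made for them only; others in the source may bear on it.

Compound 1 `Cc1nn(C)c2c1C(c1ccccc1)=NCCN2C`, compound 2 `Cc1nn(C)c2c1C(c1ccccc1Cl)=NCCN2` and compound 3 `Cc1nn(C)c2c1C(c1ccccc1Cl)=NCCN2C` share one core and were all tested in a functional assay on the whole organism for positive allosteric modulation, with Rattus norvegicus as the target; on this read-out higher numbers stand for an effect only at larger amounts of compound and lower numbers for an effect already at smaller amounts. In this assay compound 1 gives 2.5 mg/kg, compound 2 gives 2.5 mg/kg and compound 3 gives 2.5 mg/kg, so compound 3 stands level with both of its neighbours. Both measured steps were flat: no change at the digits printed from compound 1 to compound 3 (within the scatter) and no change at the digits printed from compound 2 to compound 3 (within the scatter). Compound 4 `CCn1nc(C)c2c1N(C)CCN=C2c1ccccc1Cl` has not yet been measured. It differs from compound 3 by methyl in place of hydrogen on a saturated chain carbon bound to an aromatic nitrogen; the same difference, cut one bond further out, reads methyl to ethyl. Among the compounds with values here, no measured step carries this exact change, but the two flat steps show that adding one small group to this core, whether on an aromatic carbon or on a nitrogen on an aromatic ring in a ring, left the read-out unchanged. The step to compound 4 is therefore expected to stay within the scatter as well, that is no change at the digits printed from compound 3 to compound 4 (within the scatter). For compound 4 the expected value is 2.5 mg/kg, with a range from 1.2 mg/kg to 5 mg/kg.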

Compound 4, minimum effective dose: 5 mg/kg
Compound 4: middle estimate off by 2.0-fold (0.30 log units), on the low side, within the range that was stated.
By their numbers in this assay, from the lowest: compounds 1, 2, 3 and 4 (each within the scatter of the next).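

Within the data shown here, the change from methyl to ethyl on the aromatic nitrogen reaches a place that the earlier steps, on an aromatic carbon and on a ring nitrogen, did not touch. In this assay the step reads a 2.0-fold higher number from compound 3 to compound 4 (0.30 log units; within the scatter) and so shows that this saturated chain carbon bound to an aromatic nitrogen can carry a methyl without a change beyond the scatter, the third step on this core to stay within it. Nothing on hand explains this reading.

From the compounds shown here alone, only methyl and ethyl appear at this nitrogen, so it remains open whether a longer chain such as propyl, or a chain ending in an amine or a carboxylic acid, would also stay within the scatter. Also open, going by these compounds, is whether ethyl here would read the same with hydrogen in place of the chloro, as in compound 1.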